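A few compounds are considered here, and "the series" means these few. Any claim that something is new, unique, unknown or untested is made for them only; others in the source may bear on it.

Three compounds sharing one core have numbers in a functional assay on HeLa cells (Homo sapiens) for cytotoxicity, read by MTT assay, with a stated time of 72 h; a higher number here means a weaker inhibitor, a lower number a stronger inhibitor. Compound 1 `O=C(Nc1nnc(-c2cccc(O)c2O)s1)c1ccc(Cl)cc1` gives 13000 nM, compound 2 `O=C(COc1ccccc1)Nc1nnc(-c2cccc(O)c2O)s1` gives 117000 nM, and compound 3 `CC(=O)Nc1nnc(-c2cccc(O)c2O)s1` gives 177000 nM. Compound 3 therefore lies far from compound 1, and within the scatter of compound 2. The next compound, compound 4 `O=C(Nc1nnc(-c2cccc(O)c2O)s1)C1CCCCC1`, differs from compound 3 at one place: cyclohexyl in place of methyl on a carbonyl carbon, which is cyclohexyl in place of methyl on a carbonyl carbon.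

Among the measured compounds shown here, two measured steps bear on this change. Replacing 4-chlorophenyl with methyl gave a 14-fold higher number from compound 1 to compound 3 (1.13 log units; beyond the scatter), a large step, so a ring on that carbonyl carbon went with the lower number there. Compound 2 goes against any simple rule, as its phenoxymethyl group also holds a ring, yet the change to methyl gave only a 1.5-fold higher number from compound 2 to compound 3 (0.18 log units; within the scatter), which is within the scatter. A modest move towards a lower number is therefore expected, with the estimated step being a 3.0-fold lower number from compound 3 to compound 4 (0.47 log units; beyond the scatter). Compound 4 is estimated at 60000 nM, with an expected range of 20000 nM to 170000 nM.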

Compound 4, half-maximal inhibitory concentration: 91600 nM
Estimate against measurement, compound 4: 1.5-fold (0.18 log units) below; low and high end bracket the measured number.
By their numbers in this assay, from the lowest: compound 1; then compounds 4, 2 and 3 (each within the scatter of the next).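

Cyclohexyl on the carbonyl carbon does not separate from methyl (a 1.9-fold lower number from compound 3 to compound 4 (0.29 log units; within the scatter)), and it does not separate from phenoxymethyl either (a 1.3-fold lower number from compound 2 to compound 4 (0.11 log units; within the scatter)). A carbon-only ring directly on that carbonyl carbon is therefore not enough to give a low number here, so compounds 2 and 4 both hold a ring and yet stay with the ring-free compound 3. Among these four compounds only compound 1 stands apart, and its 4-chlorophenyl group remains clearly ahead of cyclohexyl (a 7.0-fold higher number from compound 1 to compound 4 (0.85 log units; beyond the scatter)).

Going by these compounds, it remains open whether the low number of compound 1 goes with its flat benzene ring or with its chlorine, a question that a plain phenyl group on the same carbonyl carbon would address. Nothing at hand offers a reason for any of these numbers.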